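A trifluoromethyl added to compound 3

A few compounds are considered here, and "the series" means these few. Any claim that something is new, unique, unknown or untested is made for them only; others in the source may bear on it.

Compound 3 `CC(C)[C@H](NC(=O)COc1cccc2ccccc12)C(=O)N[C@@H](CC(=O)O)C(=O)COc1ccncn1` sits at the edge of what a functional assay on Jurkat cells (Homo sapiens) for inhibition (a higher number here means a weaker inhibitor, a lower number a stronger inhibitor), can report: in this assay compound 3 gives > 200000 nM, which is a limit of the assay rather than a number. Compound 1 `CC(C)c1cc(OCC(=O)[C@H](CC(=O)O)NC(=O)[C@@H](NC(=O)COc2cccc3ccccc23)C(C)C)no1` also reaches only a limit, > 200000 nM. Compound 2 `CC(C)[C@H](NC(=O)COc1cccc2ccccc12)C(=O)N[C@@H](CC(=O)O)C(=O)CSc1nncn1C` likewise stops at a limit, > 200000 nM. The steps a step that the two limits leave unreadable from compound 1 to compound 2, a step that the two limits leave unreadable from compound 1 to compound 3 and a step that the two limits leave unreadable from compound 2 to compound 3 therefore cannot be read, as the limit of > 200000 nM in this assay, at which 3 of the 3 values shown sit, shows. Compound 4 `CC(C)[C@H](NC(=O)COc1cccc2ccccc12)C(=O)N[C@@H](CC(=O)O)C(=O)COc1cc(C(F)(F)F)ncn1` differs from compound 3 by trifluoromethyl in place of hydrogen on an aromatic carbon. Within the data shown here, no measured step bears on this change, and none gives a size or a direction for it. Compound 4 is expected to stay near the same limit, an expected step of a number no higher from compound 3 to compound 4 (the limit leaves the size open). The estimate for compound 4 is 200000 nM, within a range from 30000 nM to 500000 nM.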

Compound 4, half-maximal inhibitory concentration: > 200000 nM
Compound 4: no number, only a limit; the forecaster's own chance of this, stated with the estimate: 80%; the middle value lies on the limit itself.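

Among these compounds, compound 4 also stops at a limit, so no step linking it to compound 1, compound 2 or compound 3 can be read: the limit of > 200000 nM in this assay, at which 4 of the 4 values shown sit.

What the compounds shown leave open is whether any group at this position gives a readable value in this assay at all.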